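Exchanging the 4-Fluoro-2-methoxyphenyl Group of Compound 1

The compounds below may be only part of what the source reports. "The series", "measured", "known", "first", "only" and "open" are said of these compounds alone.

Compound 1 `COc1cc(F)ccc1-c1ccnc2[nH]c(C3CCN(CC(=O)N(C)C)CC3)cc12` stands lowest of three measured compounds in a physicochemical assay for lipophilicity, using the shake flask method, measured as octanol-water partition, at pH 7.4 (on this read-out higher numbers stand for higher lipophilicity and lower numbers for lower lipophilicity), where compound 1 gives 2.9. Compound 3 `COc1cc(F)ccc1-c1ccnc2[nH]c(C3CCN(C(C)=O)CC3)cc12` gives 3.4 in this assay, and compound 2 `COc1cc(F)ccc1-c1ccnc2[nH]c(C3CCOCC3)cc12` sits highest, with a reading of 3.9. Both measured steps concern the group attached to the saturated six-membered ring at the far end of the shared core: a number 0.50 log units higher from compound 1 to compound 3 (beyond the scatter), and a number 0.50 log units lower from compound 2 to compound 3 (beyond the scatter). Each step is modest and beyond the scatter, and together they account for the whole separation between compound 1 and compound 2.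

Compound 4 `COc1cc(=O)n(C)cc1-c1ccnc2[nH]c(C3CCN(CC(=O)N(C)C)CC3)cc12` differs from compound 1 at a different place entirely: a group of 10 heavy atoms (7 carbon, 1 nitrogen, 2 oxygen; one six-membered aromatic ring with 1 hetero atom) in place of a group of 9 heavy atoms (7 carbon, 1 oxygen, 1 fluorine; one six-membered aromatic ring of carbon only), on an aromatic carbon. For the measured compounds named here, neither measured step touches the position where the 4-fluoro-2-methoxyphenyl group sits, so the three measured compounds give no direct precedent for this exchange. The change removes the fluorine and the carbon-only aromatic ring and introduces a ring with a hetero atom and a double bond outside aromatic rings. A downward step, larger than either measured step, is therefore expected: a number 1.50 log units lower from compound 1 to compound 4 (beyond the scatter). Compound 4 is estimated to give 1.4 in this assay, with a range from 0.6 to 2.2.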

Compound 4, distribution coefficient: 0.7
Compound 4: the middle estimate sits 0.70 log units above what was measured; measured number inside the range.
By their numbers in this assay, from the lowest: compound 4; then compound 1; then compound 3; then compound 2.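

In this assay, exchanging the 4-fluoro-2-methoxyphenyl group on the aromatic carbon opposite the ring nitrogen gives a number 2.20 log units lower from compound 1 to compound 4 (beyond the scatter) and this step is large. It is the first reading at this position, and it shows the read-out moving further here than in either change to the group on the saturated ring at the far end of the shared core, such as (a number 0.50 log units higher from compound 1 to compound 3 (beyond the scatter)), so that among the compounds shown this position carries the largest single step. No measurement shows which part of the exchange accounts for this size, whether the loss of the fluorine, the hetero atom in the entering ring, or its double bond outside aromatic rings.

As far as these compounds go, it remains open whether the same exchange would produce a step of similar size on compound 2 or compound 3, whose groups at the far end differ from that of compound 1. The compounds shown also leave open where a plain phenyl ring or a pyridine ring carrying only a methoxy group would fall at this position, and such groups could separate the parts of this exchange.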